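A few compounds are considered here, and "the series" means these few. Any claim that something is new, unique, unknown or untested is made for them only; others in the source may bear on it.

Measured so far in an assay on isolated protein with Bile acid receptor (Homo sapiens) as the target; on this read-out higher numbers stand for an effect only at larger amounts of compound and lower numbers for an effect already at smaller amounts:
compound 1, `COC(=O)/C=C/c1cccc(N(Cc2ccc3c(c2OC)OC(C)(C)C=C3)C(=O)C2CCCCC2)c1`, which in this assay gives 358 nM;
compound 2, `COC(=O)/C=C/c1ccc(CN(C(=O)C2CCCCC2)c2cccc(/C=C/C(=O)OC)c2)cc1`, which in this assay gives > 1000 nM.

For compound 2 this value is only a limit of this assay and not a number; it stands at the limit of > 1000 nM in this assay, at which 1 of the 2 values shown sits. Compound 3, `COC(=O)/C=C/c1cccc(N(Cc2ccc(-c3cccc(OC(F)(F)F)c3)cc2)C(=O)C2CCCCC2)c1`, has not yet been measured. It differs from compound 2 by 3-(trifluoromethoxy)phenyl in place of 2-(methoxycarbonyl)ethenyl on an aromatic carbon. Going by the values given here, no step between two measured compounds is available, so the size of the change can only be expected. Compound 3 is estimated at 600 nM, in the range 200 nM to 2500 nM. The expected step of an at least 1.6-fold lower number from compound 2 to compound 3 (0.22 log units; that floor lies within the scatter) is toward an effect at smaller amounts, beyond the usual scatter.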

Compound 3, half-maximal effective concentration: 420 nM
The estimate for compound 3 lay 1.4-fold (0.15 log units) above the measured number; the range from low to high includes it.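

In this assay, 3-(trifluoromethoxy)phenyl in place of 2-(methoxycarbonyl)ethenyl, on an aromatic carbon para to a large group, gives an at least 2.3-fold lower number from compound 2 to compound 3 (0.37 log units; beyond the scatter) as a step with a floor only. For compound 2 the value is a limit of the assay and not a number, so the full size of the step cannot be read: the limit of > 1000 nM in this assay, at which 1 of the 3 values shown sits. Going by these compounds alone, this position thus carries a larger aromatic group with a measurable value, which the earlier compounds did not show.

Whether the ring itself or its trifluoromethoxy group accounts for the step remains open. From the compounds shown here alone, what a plain phenyl, an amine or a carboxylic acid would give at this position also remains open.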